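Pyrimidinyl in Place of Fluorophenyl on a Ketooxazole Scaffold

The source may hold more compounds than are shown below. What is called first, only, known or untested is meant among the compounds shown, and "the series" means these compounds.

Measured compounds:
Compound 1, `O=C(CCCCCCc1ccccc1)c1ncc(-c2ccccc2F)o1`: 110 nM
Compound 2, `NC(=O)c1cccc(-c2cnc(C(=O)CCCCCCc3ccccc3)o2)c1`: 6 nM
Compound 3, `N#Cc1cccc(-c2cnc(C(=O)CCCCCCc3ccccc3)o2)c1`: 15 nM

In an assay (Rattus norvegicus) for inhibition of Fatty-acid amide hydrolase 1 (Homo sapiens) (a lower number here means a stronger inhibitor, a higher number a weaker inhibitor), compound 1 gives the highest of the three numbers. Its nearest neighbour is compound 3, reached by a 7.3-fold lower number from compound 1 to compound 3 (0.87 log units; beyond the scatter); furthest is compound 2, reached by an 18-fold lower number from compound 1 to compound 2 (1.26 log units; beyond the scatter). Between those two aryl groups, a 2.5-fold higher number from compound 2 to compound 3 (0.40 log units; beyond the scatter).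

Compound 4, `O=C(CCCCCCc1ccccc1)c1ncc(-c2ccncn2)o1`, differs from compound 1 in one place: pyrimidin-4-yl in place of 2-fluorophenyl on an aromatic carbon.

Both measured steps from compound 1 replaced the 2-fluorophenyl with a ring carrying hydrogen-bond acceptors and both lowered the number beyond the scatter, one a large step and one a modest one. Among the measured compounds shown here, the change to pyrimidin-4-yl likewise brings in two hydrogen-bond acceptors, though within the ring itself rather than on a substituent, so no directly matching step exists. On that basis compound 4 is expected to show a lower number than compound 1, about an 11-fold lower number from compound 1 to compound 4 (1.04 log units; beyond the scatter), a step of size between those two observed. The estimate for compound 4 is 10 nM, with a range of 3 nM to 40 nM.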

Compound 4, inhibition constant: 2.3 nM
For compound 4 the middle estimate is 4.3-fold (0.64 log units) above the measured one; the measured number lies below the stated range.
By their numbers in this assay, from the lowest: compound 4; then compound 2; then compound 3; then compound 1.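

In this assay, pyrimidin-4-yl on this aromatic carbon, next to the ring oxygen, gives the lowest number of the four compounds (a 48-fold lower number from compound 1 to compound 4 (1.68 log units; beyond the scatter)). This unsubstituted ring, with its hetero atoms inside it, also goes beyond both substituted phenyl rings (a 6.5-fold lower number from compound 3 to compound 4 (0.81 log units; beyond the scatter); a 2.6-fold lower number from compound 2 to compound 4 (0.42 log units; beyond the scatter)), so a substituent on a phenyl ring is not needed for a low number at this position. Nothing measured here explains why this ring gives the lowest number.

As far as these compounds go, whether both ring nitrogens are needed, and whether their placement matters, stays open, since a pyridin-2-yl or pyrimidin-5-yl group would be needed to separate these. From the compounds shown here alone, it is also open whether an amine or a carboxylic acid on the pyrimidine ring would lower the number further.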